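Hydrazone aryl variation at the shared core: compound 4

The source may hold more compounds than are shown below. What is called first, only, known or untested is meant among the compounds shown, and "the series" means these compounds.

Measured so far in an assay on CHO-K1 cells for displacement of a labelled ligand from adenosine receptor A1 (Homo sapiens), read by scintillation counting, with a stated time of 60 min; on this read-out higher numbers stand for weaker inhibition and lower numbers for stronger inhibition:
compound 1 `N#Cc1ccc(/C=N/Nc2nc(N)c3ncn([C@@H]4O[C@H](CO)[C@@H](O)[C@H]4O)c3n2)cc1`, 4.1 nM
compound 2 `Nc1nc(N/N=C/c2ccc(N3CCCC3)cc2)nc2c1ncn2[C@@H]1O[C@H](CO)[C@@H](O)[C@H]1O`, 5.1 nM
compound 3 `Nc1nc(N/N=C/c2cncs2)nc2c1ncn2[C@@H]1O[C@H](CO)[C@@H](O)[C@H]1O`, 22 nM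

Compound 2 stands second highest of the three numbers; its nearest neighbour is compound 1, a 1.2-fold higher number from compound 1 to compound 2 (0.09 log units; within the scatter), and compound 3 lies furthest, a 4.3-fold higher number from compound 2 to compound 3 (0.63 log units; beyond the scatter). Compound 4 `Nc1nc(N/N=C/c2ccc(-c3ccccc3)cc2)nc2c1ncn2[C@@H]1O[C@H](CO)[C@@H](O)[C@H]1O` differs from compound 2 as follows: phenyl in place of pyrrolidin-1-yl on an aromatic carbon. For the measured compounds named here, the step that bears most on this is the one from compound 1 to compound 2, a change of the substituent on the same aromatic carbon, which was a 1.2-fold higher number from compound 1 to compound 2 (0.09 log units; within the scatter). The steps to compound 3 replace the whole aryl group and matter less: a 5.4-fold higher number from compound 1 to compound 3 (0.73 log units; beyond the scatter). For compound 4 a step within the scatter is expected, a 1.3-fold higher number from compound 2 to compound 4 (0.11 log units; within the scatter). Compound 4 is estimated at 6.5 nM, range 2.5 nM to 17 nM.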

Compound 4, inhibition constant: 7860 nM
The estimate for compound 4 lay 1200-fold (3.08 log units) below the measured number, and the stated range ends below it.
By their numbers in this assay, from the lowest: compounds 1 and 2 (each within the scatter of the next); then compound 3; then compound 4.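

In this assay, the substituent on this aromatic carbon seemed not to matter between cyano and pyrrolidin-1-yl (a 1.2-fold higher number from compound 1 to compound 2 (0.09 log units; within the scatter)), but phenyl in the same place changes the picture (a 1500-fold higher number from compound 2 to compound 4 (3.19 log units; beyond the scatter)) and (a 1900-fold higher number from compound 1 to compound 4 (3.28 log units; beyond the scatter)). The tolerance seen with compound 1 and compound 2 therefore does not extend to every group at this carbon, and compound 4 goes against any reading of the position as indifferent. Nothing available explains the loss.

From the compounds shown here alone, whether the drop belongs to the aromatic ring or to any all-carbon substituent remains open. Cyclohexyl or methyl at the same carbon, or piperidin-1-yl as a close relative of pyrrolidin-1-yl, would bear on that question.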